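The source may report more compounds than this note shows. Statements on the series, on what has been measured and on what is new or still open speak of the compounds shown alone.

Measured so far in an assay on isolated protein for inhibition of Amine oxidase [flavin-containing] B (Homo sapiens), read by fluorescence, with stated times of 15 min and 20 min; on this read-out lower numbers stand for stronger inhibition and higher numbers for weaker inhibition:

compound 1 `COc1ccc(CN2CCC(CCNC(=O)/C=C/c3cc(C(C)(C)C)c(O)c(C(C)(C)C)c3)CC2)cc1` gives 6700 nM
compound 2 `Cc1ccccc1CN1CCC(CCNC(=O)/C=C/c2cc(C(C)(C)C)c(O)c(C(C)(C)C)c2)CC1` gives 7200 nM
compound 3 `CC(C)(C)c1cc(/C=C/C(=O)NCCC2CCN(Cc3ccc(F)cc3)CC2)cc(C(C)(C)C)c1O` gives 11100 nM

Compound 3 has the highest of the three numbers in this assay, but its nearest neighbour, compound 2, lies a step away that the data mark as within the scatter (a 1.5-fold higher number from compound 2 to compound 3 (0.19 log units; within the scatter)), and the step from compound 1 is likewise within the scatter (a 1.7-fold higher number from compound 1 to compound 3 (0.22 log units; within the scatter)). All three benzyl variants on the shared core therefore sit in one band, with no order among them that the numbers can support.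

Compound 4 `CC(C)(C)c1cc(/C=C/C(=O)NCCC2CCN(Cc3ccc(F)c(F)c3)CC2)cc(C(C)(C)C)c1O` carries the change (fluoro in place of hydrogen on an aromatic carbon). Among the measured compounds shown here, no measured step changes the same position in the same way, so nothing bears on it directly. What the series does show is that swapping the substituent on the benzyl ring — methoxy to methyl (a 1.1-fold higher number from compound 1 to compound 2 (0.03 log units; within the scatter)), methoxy to fluoro (a 1.7-fold higher number from compound 1 to compound 3 (0.22 log units; within the scatter)) — leaves this assay essentially unmoved. Adding a second fluoro is a smaller alteration than any of those swaps, so no step beyond the scatter is expected, in either direction.

Compound 4 is therefore estimated at 11000 nM, with a range of 4500 nM to 27000 nM; the expected step is a 1.0-fold lower number from compound 3 to compound 4 (0.00 log units; within the scatter).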

Compound 4, half-maximal inhibitory concentration: 9300 nM
Compound 4: the middle estimate sits 1.2-fold (0.07 log units) above what was measured; low and high end bracket the measured number.
By their numbers in this assay, from the lowest: compounds 1, 2, 4 and 3 (each within the scatter of the next).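

In this assay, among the compounds shown here, fluoro in place of hydrogen on the 4-fluorobenzyl group, at the aromatic carbon ortho to a fluoro group, gives the first direct reading of this position (a 1.2-fold lower number from compound 3 to compound 4 (0.08 log units; within the scatter)), and the step stays within the scatter. The 3,4-difluorobenzyl group also stays within the scatter of the other two benzyl variants (a 1.3-fold higher number from compound 2 to compound 4 (0.11 log units; within the scatter); a 1.4-fold higher number from compound 1 to compound 4 (0.14 log units; within the scatter)), so the band now covers an added substituent as well as swaps of one substituent for another. Nothing given here accounts for this flat reading.

Still open, as far as these compounds go, is whether any group on this benzyl ring moves the number beyond the scatter, for example a carboxylic acid, a dimethylamino group or a second fluoro-free substituent such as trifluoromethyl at the same aromatic carbon. All four compounds also share the rest of the core, so the compounds shown say nothing about a change elsewhere, such as a longer chain between the amide nitrogen and the ring bearing the benzyl group.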